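Chloro addition on the core of compound 1

The source may hold more compounds than are shown below. What is called first, only, known or untested is meant among the compounds shown, and "the series" means these compounds.

Going by the values given here, compound 1 `c1cc(-c2ccn[nH]2)c2c(c1)C(c1ncc[nH]1)CC2` gives 600 nM in a functional assay on CHO cells for agonist activity at Alpha-1B adrenergic receptor (Homo sapiens), read by FLIPR and calcium flux (on this read-out lower numbers stand for an effect already at smaller amounts and higher numbers for an effect only at larger amounts of compound), and is the only compound with a measured number so far. Compound 2 `c1cncc(-c2cccc3c2CCC3c2ncc[nH]2)c1` reaches only > 10000 nM in this assay, which is the limit of > 10000 nM in this assay, at which 1 of the 2 values shown sits. The step of an at least 16-fold higher number from compound 1 to compound 2 (1.22 log units; beyond the scatter) goes with pyridin-3-yl in place of 1H-pyrazol-5-yl on an aromatic carbon. Compound 3 `Clc1ccc2c(c1-c1ccn[nH]1)CCC2c1ncc[nH]1` differs from compound 1 by chloro in place of hydrogen on an aromatic carbon. That measured step exchanges the pyrazolyl ring itself, so it bears only loosely on a chloro addition with the ring kept. A step within the scatter, in either direction, is expected in this assay. Compound 3 is estimated at 500 nM (range 150 nM to 1500 nM), which means an expected step of a 1.2-fold lower number from compound 1 to compound 3 (0.08 log units; within the scatter).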

Compound 3, half-maximal effective concentration: > 10000 nM
Compound 3: a limit, no number (the forecaster's own chance of this, stated with the estimate: 10%); middle value at least 20-fold (1.30 log units) from the limit.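

On the aromatic carbon ortho to the 1H-pyrazol-5-yl group, a single chloro in place of hydrogen, with the pyrazolyl ring kept, goes with an at least 16-fold higher number from compound 1 to compound 3 (1.22 log units; beyond the scatter). A change on the core of compound 1 can therefore cost as much of the read-out as the exchange of the ring itself. For compound 3 the value is a limit and not a number, and it stands with compound 2 there: the limit of > 10000 nM in this assay, at which 2 of the 3 values shown sit.

On these data alone, how far compound 3 lies past that limit stays open. So does whether fluoro, methyl or an amine on this carbon would keep a measurable value in this assay.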